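This account rests on a few compounds, and the source may have more. Where it says the series, first, only, none or still open, it means among the compounds named here.

Compound 1 `CCOc1ccc(C(=O)NNc2c(Br)cccc2Br)cc1` and compound 2 `CC(C)(C)c1ccc(C(=O)NNc2c(Br)cccc2Br)cc1` differ only by tert-butyl in place of ethoxy on an aromatic carbon. In a toxicity assay on MDCK cells (Canis lupus familiaris) for cytotoxicity, read by CCK-8 assay, with a stated time of 48 h (on this read-out higher numbers stand for lower toxicity in this test and lower numbers for higher toxicity in this test), compound 1 gives only a limit of the assay and not a number, > 100000 nM. Compound 2 likewise reaches a limit in this assay, > 100000 nM. The step that the two limits leave unreadable from compound 1 to compound 2 therefore cannot be read, because the limit of > 100000 nM in this assay, at which 3 of the 3 values shown sit, holds both values. Compound 3 `CCOc1ccc(C(=O)NNc2c(C)cccc2C)cc1` has a different core; the difference between the two cores is not broken down here. In this assay compound 3 also reports a limit, > 100000 nM. Compound 4 `Cc1cccc(C)c1NNC(=O)c1ccc(C(C)(C)C)cc1` carries the same change as before, (tert-butyl in place of ethoxy on an aromatic carbon), placed on the core of compound 3. Since the measured step reached only the limit (the limit of > 100000 nM in this assay, at which 3 of the 3 values shown sit), the step that the limit leaves unreadable from compound 3 to compound 4 is expected to be of the same unreadable kind. Compound 4 is accordingly estimated at 150000 nM, most likely again a limit.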

Compound 4, half-maximal cytotoxic concentration: > 100000 nM
Compound 4: no number, only a limit; the forecaster's own chance of this, stated with the estimate: 90%; the middle value lies beyond the limit too.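

The step from compound 3 to compound 4 cannot be read, as both compounds sit at a limit: the limit of > 100000 nM in this assay, at which 4 of the 4 values shown sit. As far as these compounds go, how toxic these compounds are in this assay, and whether swapping ethoxy for tert-butyl changes that, stays open.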